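Para substituent on the anilide ring: methyl replacing methoxy

This account rests on a few compounds, and the source may have more. Where it says the series, first, only, none or still open, it means among the compounds named here.

Compound 1 `COc1ccc(NS(=O)(=O)c2ccc(N3CCNC3=O)cc2)cc1` gives 800 nM in a functional assay on HT-29 cells (Homo sapiens) for antiproliferative activity, read by sulforhodamine B assay, with a stated time of 48 h; on this read-out higher numbers stand for weaker inhibition and lower numbers for stronger inhibition. Among the two plain numbers measured so far this is the highest; its nearest neighbour is compound 3 `O=C1NCCN1c1ccc(S(=O)(=O)Nc2ccccc2)cc1`, which gives 280 nM in this assay, the step from compound 1 being a 2.9-fold lower number from compound 1 to compound 3 (0.46 log units; beyond the scatter). Compound 2 `O=C1NCCN1c1ccc(S(=O)(=O)Nc2ccc(C3CCCCC3)cc2)cc1` reaches only the limit of this assay, > 1000 nM, as noted in the limit of > 1000 nM in this assay, at which 1 of the 3 values shown sits. The step of an at least 1.2-fold higher number from compound 1 to compound 2 (0.09 log units; that floor lies within the scatter) is therefore a floor, and the step of an at least 3.5-fold lower number from compound 2 to compound 3 (0.55 log units; beyond the scatter) likewise.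

Compound 4 `Cc1ccc(NS(=O)(=O)c2ccc(N3CCNC3=O)cc2)cc1` has not yet been measured in this assay. It differs from compound 1 in one place: methyl in place of methoxy on an aromatic carbon. The two steps that bear on it are those leaving compound 1 at the same aromatic carbon, toward hydrogen in compound 3 and toward cyclohexyl in compound 2. Removing the group lowered the number by a modest amount; enlarging it raised the number into the limit. Methyl, with one heavy atom, sits between those two cases, so the expected step is either a small lowering or none beyond the scatter.

For compound 4 a value of 500 nM is expected in this assay, between 200 nM and 1300 nM, a step of a 1.6-fold lower number from compound 1 to compound 4 (0.20 log units; within the scatter).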

Compound 4, half-maximal inhibitory concentration: 480 nM
Beside the measured number, compound 4's estimate is 1.0-fold (0.02 log units) above it; the measured number falls inside the stated range.
By their numbers in this assay, from the lowest: compounds 3, 4 and 1 (each within the scatter of the next, the first and the last beyond it). At a limit, above all of these: compound 2.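

In this assay, methyl and methoxy on this aromatic carbon cannot be told apart: a 1.7-fold lower number from compound 1 to compound 4 (0.22 log units; within the scatter). Methyl and hydrogen cannot be told apart either: a 1.7-fold higher number from compound 3 to compound 4 (0.23 log units; within the scatter). Compound 4 therefore lies within the scatter of both compound 1 and compound 3, although those two differ beyond it, so the series so far shows no sharp break among these small groups, and the oxygen of methoxy is not shown to matter on its own. Cyclohexyl is the one group here clearly set apart from methyl, with an at least 2.0-fold lower number from compound 2 to compound 4 (0.31 log units; beyond the scatter) as a floor and not a measured size, since compound 2 stands at a limit: the limit of > 1000 nM in this assay, at which 1 of the 4 values shown sits.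

The compounds shown leave open how an amine, a hydroxyl or a carboxylic acid on this aromatic carbon would read in this assay, so only carbon-based and methoxy groups inform this position. They also leave open how an ethyl group or a longer chain would read, and so at what size the number moves beyond the scatter of compound 4.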